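The compounds below may be only part of what the source reports. "The series", "measured", "known", "first", "only" and "open" are said of these compounds alone.

So far, three compounds have values in a functional assay on MCF7 cells (Homo sapiens) for inhibition, read by MTT assay, with a stated time of 72 h (on this read-out lower numbers stand for stronger inhibition and higher numbers for weaker inhibition), and one is still to be measured.
- Compound 1 `COc1cc(OC)c(OC)cc1/C=C/C(=O)c1ccc(O)cc1O` gives 33800 nM
- Compound 2 `COc1cc(OC)c(OC)cc1/C=C/C(=O)c1cc(O)ccc1O` gives > 150000 nM as a limit
- Compound 3 `COc1cc(OC)c(OC)cc1/C=C/C(=O)c1ccc([N+](=O)[O-])cc1` gives > 150000 nM as a limit

Compound 3 has no true number, because its > 150000 nM is only a limit of the assay. It sits at the limit of > 150000 nM in this assay, at which 2 of the 3 values shown sit, and shares that limit with compound 2.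

Compound 4 `COc1cc(OC)c(OC)cc1/C=C/C(=O)c1ccc(Br)cc1` keeps the core of compound 3 and changes one group in this way: bromo in place of nitro on an aromatic carbon. For the measured compounds named here, no measured step involves either bromo or nitro. The closest evidence is an at least 4.4-fold higher number from compound 1 to compound 2 (0.64 log units; beyond the scatter), which also changes the group on the carbonyl carbon. It suggests that a change on this part of the molecule can move the result in this assay beyond the scatter, but it says little about this particular swap. Compound 1 also shows that this series can give a real number, with 33800 nM as its result.

Starting from a limit, only a move toward a lower number could be seen, and compound 4 may well stay at the limit. The expected change, modest in size, is an at least 2.5-fold lower number from compound 3 to compound 4 (0.39 log units; beyond the scatter). For compound 4 the estimated value is 60000 nM, with an expected range from 15000 nM to 150000 nM.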

Compound 4, half-maximal inhibitory concentration: 18300 nM
Compound 4: middle estimate off by 3.3-fold (0.52 log units), on the high side; the measured number falls inside the stated range.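

In this assay, placing bromo instead of nitro on this aromatic carbon, para to a large group, turns a result held at a limit into a real number, with an at least 8.1-fold lower number from compound 3 to compound 4 (0.91 log units; beyond the scatter) as the step. From the compounds shown here alone, its true size stays unknown, since the step starts from a limit that compound 3 shares with compound 2: the limit of > 150000 nM in this assay, at which 2 of the 4 values shown sit. The second step, an at least 8.1-fold lower number from compound 2 to compound 4 (0.91 log units; beyond the scatter), also starts from a limit, whereas a 1.8-fold lower number from compound 1 to compound 4 (0.27 log units; within the scatter) means that 4-bromophenyl and 2,4-dihydroxyphenyl cannot be told apart on this read-out, so a ring with only a bromo group does as well here as the better of the two dihydroxyphenyl rings.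

Going by these compounds, what remains open is whether bromo itself matters or whether other groups at this position, such as chloro, an amine, a carboxylic acid or a plain hydrogen, would also give real numbers. The compounds shown also do not tell why nitro and bromo differ, and with a single bromo compound no trend across this position can be drawn.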